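The source may report more compounds than this note shows. Statements on the series, on what has been measured and on what is new or still open speak of the compounds shown alone.

Compound 1, `CC1=C(C(=O)C2CC2)C(c2cccs2)NC(=O)N1`, in an assay on membranes from HeLa cells for displacement of a labelled ligand from adenosine receptor A3 (Homo sapiens), read by scintillation counting, with a stated time of 180 min, tested at 1 uM (on this read-out lower numbers stand for less inhibition and higher numbers for more inhibition at the one concentration tested (going by the name of the read-out)), gives 15%.
Compound 2, `CCSC(=O)C1=C(C)NC(=O)NC1c1cccs1`, gives 1%.
Compound 3, `CCC(C)OC(=O)C1=C(C)NC(=O)NC1c1cccs1`, gives 7%.

All three share one core and differ only in the group attached to the carbonyl carbon. Compound 3 stands second highest of the three numbers, but its neighbours are close: the step of a number 6 percentage points higher from compound 2 to compound 3 (within the scatter) and the step of a number 8 percentage points lower from compound 1 to compound 3 (within the scatter) are both within the scatter, so no order among the three can be read. Among the measured compounds shown here, only the step of a number 14 percentage points lower from compound 1 to compound 2 (beyond the scatter) reaches beyond the scatter.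

Compound 4, `CC1=C(C(=O)OCC2CC2)C(c2cccs2)NC(=O)N1`, has not yet been measured. It differs from compound 3 in one place: cyclopropylmethyl in place of sec-butyl on an oxygen next to a carbonyl group. The measured steps that bear on this are those ending at compound 3, where sec-butoxy replaced cyclopropyl on a carbonyl carbon and sec-butoxy replaced ethylsulfanyl, both within the scatter. For the measured compounds named here, no measured step changes the alkyl group on the oxygen itself. Compound 4 is therefore expected to show a step of a number 1 percentage points higher from compound 3 to compound 4 (within the scatter), not beyond the scatter. The estimate for compound 4 is 8%, between 0% and 20%.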

Compound 4, a percentage reported as inhibition, at one concentration (the size of the read-out at that concentration, not a potency): 1%
Estimate against measurement, compound 4: 7 percentage points above, and the stated range covers the measured number.
By their numbers in this assay, from the lowest: compounds 2, 4, 3 and 1 (each within the scatter of the next, the first and the last beyond it).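

At the oxygen itself, the step of a number 6 percentage points lower from compound 3 to compound 4 (within the scatter) shows that in this assay cyclopropylmethyl, which has a ring, cannot be told apart from sec-butyl, which has none, and the step of no change at the digits printed from compound 2 to compound 4 (within the scatter) likewise does not separate cyclopropylmethoxy from ethylsulfanyl on the carbonyl carbon. The step of a number 14 percentage points lower from compound 1 to compound 4 (beyond the scatter) gives a second replacement of the cyclopropyl on the carbonyl carbon that reaches beyond the scatter, although compound 3, with sec-butoxy there, goes against this pattern, as its own step from compound 1 stays within the scatter. Nothing measured here explains these steps.

The compounds shown leave open whether an amine or a carboxylic acid on the carbonyl carbon, or a longer chain on the oxygen, would give a step beyond the scatter from compound 3. They also leave open how potent any of these compounds is, since a reading at one concentration is not a potency.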